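A few compounds are considered here, and "the series" means these few. Any claim that something is new, unique, unknown or untested is made for them only; others in the source may bear on it.

The series shares a core shown in compound 1 `CC(C)(C)OC(=O)Nc1ccc(C#CCCCCC(=O)c2ncc(-c3ccccn3)o2)cc1`, which in an assay for inhibition of Fatty-acid amide hydrolase 1 (Rattus norvegicus) (on this read-out higher numbers stand for weaker inhibition and lower numbers for stronger inhibition), gives 23 nM. Compound 2 `O=C(CCCCC#Cc1cccc([N+](=O)[O-])c1)c1ncc(-c2ccccn2)o1` gives 4.8 nM in this assay. Compound 3 `O=C(CCCCCCc1ccccc1C(=O)O)c1ncc(-c2ccccn2)o1` is reported in this assay only as a limit, > 600 nM, and so stands at the limit of > 600 nM in this assay, at which 1 of the 3 values shown sits, rather than at a number. No step between two measured compounds is shown here, so the two values of compound 1 and compound 2 are simply what they show. Compound 4 `CSc1ccc(CCCCCCC(=O)c2ncc(-c3ccccn3)o2)cc1` differs from compound 3 by 4-(methylsulfanyl)phenyl in place of 2-carboxyphenyl on a saturated chain carbon, six bonds along the chain from a carbonyl carbon. A large step toward stronger inhibition, well beyond the scatter, is expected an at least 40-fold lower number from compound 3 to compound 4 (1.60 log units; beyond the scatter), and compound 4 is estimated in this assay at 15 nM, within a range from 4 nM to 60 nM.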

Compound 4, inhibition constant: 2.5 nM
Compound 4: the middle estimate sits 6.0-fold (0.78 log units) above what was measured, and the stated range ends above it.
By their numbers in this assay, from the lowest: compounds 4 and 2 (each within the scatter of the next); then compound 1. At a limit, above all of these: compound 3.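

In this assay, 4-(methylsulfanyl)phenyl in place of 2-carboxyphenyl on a saturated chain carbon, six bonds along the chain from a carbonyl carbon, gives an at least 240-fold lower number from compound 3 to compound 4 (2.38 log units; beyond the scatter). Among the compounds shown here, this is the first step that can be read, and it shows that the group at this place can change the read-out far beyond the scatter. Compound 3 is reported only as a limit, and the full size of the step stays unknown: the limit of > 600 nM in this assay, at which 1 of the 4 values shown sits.

The compounds shown leave open how a 4-carboxyphenyl group or an unsubstituted phenyl group would read at this place. They therefore do not settle whether the carboxylic acid itself or the pattern of substitution on the ring carries the step.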